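The source may report more compounds than this note shows. Statements on the series, on what has been measured and on what is new or still open speak of the compounds shown alone.

Measured compounds:
compound 1, `CCCCCCCCCCCCCCCCCCNC(=O)[C@H]1CSC(c2c[nH]c3ccccc23)N1`, 11500 nM 
compound 2, `CCCCCCCCCCCCCCCCCCNC(=O)[C@H]1CSC(c2ccc(Br)cc2)N1`, 17300 nM 
compound 3, `CCCCCCCCCCCCCCCCCCNC(=O)[C@H]1CSC(c2ccc(C#N)cc2)N1`, not yet measured

Among the compounds with values here, in a functional assay on PC-3 cells (Homo sapiens) for antiproliferative activity, read by sulforhodamine B assay (on this read-out higher numbers stand for weaker inhibition and lower numbers for stronger inhibition), compound 2 gives 17300 nM, and this value and that of compound 1 lie within the scatter of each other; the single measured step, a 1.5-fold higher number from compound 1 to compound 2 (0.18 log units; within the scatter), concerns the group on the saturated ring carbon. Compound 3 differs from compound 2 by cyano in place of bromo on an aromatic carbon. Within the data shown here, no measured step varies a substituent on this phenyl ring, so nothing bears directly on the change, and the step from compound 2 to compound 3 is expected to stay within the scatter, a 1.2-fold higher number from compound 2 to compound 3 (0.06 log units; within the scatter). For compound 3 the estimate is 20000 nM, with a range of 8000 nM to 50000 nM.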

Compound 3, half-maximal inhibitory concentration: > 20000 nM
Compound 3: a limit, no number; the forecaster's own chance of this, stated with the estimate: 20%; the middle value sits exactly at the limit.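

In this assay compound 3 gives > 20000 nM, which is a limit of the assay and not a number. Within the data shown here, this is the first substituent change on this phenyl ring: cyano in place of bromo gives an at least 1.1-fold higher number from compound 2 to compound 3 (0.06 log units; that floor lies within the scatter), and 4-cyanophenyl in place of 1H-indol-3-yl gives an at least 1.7-fold higher number from compound 1 to compound 3 (0.24 log units; that floor lies within the scatter), so both floors show no difference beyond the scatter. The true size of either step cannot be read, because the read-out for compound 3 ends at a limit: the limit of > 20000 nM in this assay, at which 1 of the 3 values shown sits.

Open, as far as these compounds go, is how an amine or a carboxylic acid in place of bromo would read. Also open, from the compounds shown here alone, is whether a shorter chain on the amide nitrogen would shift the values of this series.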